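The source may report more compounds than this note shows. Statements on the series, on what has been measured and on what is new or still open speak of the compounds shown alone.

In a physicochemical assay for lipophilicity, at pH 7.4 (a higher number here means a more lipophilic compound, a lower number a more polar compound), three compounds that differ only in one group have been measured. Compound 1 `O=C(CCS(=O)(=O)c1ccc2cc(Cl)ccc2c1)N1CCC(c2cnc3ccccn23)CC1` gives 2.5, compound 3 `Cc1ncc2n1C(=O)N(C1CCN(C(=O)CCS(=O)(=O)c3ccc4cc(Cl)ccc4c3)CC1)C2` gives 2.3, and compound 2 `O=C(CCS(=O)(=O)c1ccc2cc(Cl)ccc2c1)N1CCC(c2cnc[nH]2)CC1` gives 2. Compound 2 therefore stands within the scatter of compound 3 but clearly apart from compound 1.

Compound 4 `Cc1nc(C)n2c1CN(C1CCN(C(=O)CCS(=O)(=O)c3ccc4cc(Cl)ccc4c3)CC1)C2=O` departs from compound 2 in one place: a group of 11 heavy atoms (7 carbon, 3 nitrogen, 1 oxygen; one five-membered non-aromatic ring with 2 hetero atoms, one five-membered aromatic ring with 2 hetero atoms) in place of a group of 5 heavy atoms (3 carbon, 2 nitrogen; one five-membered aromatic ring with 2 hetero atoms), on a saturated ring carbon. The 1H-imidazol-5-yl group leaves, and the group that enters has two rings and no hydrogen-bond donors.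

The closest guide is compound 3, whose group also has one five-membered non-aromatic ring and one five-membered aromatic ring. That swap gave a number 0.30 log units higher from compound 2 to compound 3 (within the scatter). The other change at this carbon, a number 0.50 log units lower from compound 1 to compound 2 (beyond the scatter), shows that such swaps have so far moved the number only modestly. A modest rise is therefore expected in this assay, and the estimated step is a number 0.50 log units higher from compound 2 to compound 4 (beyond the scatter). For compound 4 the expected value is 2.5, with an estimated range from 2.1 to 2.9.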

Compound 4, distribution coefficient: 2.5
For compound 4 middle estimate and measured number coincide at the digits printed; low and high end bracket the measured number.
By their numbers in this assay, from the lowest: compounds 2, 3, 1 and 4 (each within the scatter of the next, the first and the last beyond it).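

In this assay the group of compound 4 gives a number 0.50 log units higher from compound 2 to compound 4 (beyond the scatter) and so joins compound 1 as a group that stands clearly apart from the 1H-imidazol-5-yl group of compound 2. The two larger groups differ in their rings and atoms, yet the comparison gives no change at the digits printed from compound 1 to compound 4 (within the scatter) and so shows that different two-ring groups on this saturated ring carbon can give the same number. The single methyl in place of hydrogen on an aromatic carbon gives only a number 0.20 log units higher from compound 3 to compound 4 (within the scatter) and therefore cannot, by itself, be read as a real shift.

Nothing here accounts for why these groups give the numbers they do. On these data alone, it also remains open how the number would respond at this carbon to a simple amine, a carboxylic acid or a longer chain in place of these ring groups.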